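Amide tail variation in a melanocortin receptor 4 binding series

A few compounds are considered here, and "the series" means these few. Any claim that something is new, unique, unknown or untested is made for them only; others in the source may bear on it.

Compound 1 `CC(C)C[C@H](N)c1cc(C(F)(F)F)ccc1N1CCN(C(=O)C(C)Cc2ccc(Cl)c(Cl)c2)CC1`: 120 nM; 1600 nM (2 entries) in an assay on HEK293 cells for displacement of a labelled ligand from Melanocortin receptor 4 (Homo sapiens); on this read-out lower numbers stand for stronger inhibition and higher numbers for weaker inhibition
Compound 2 `CC(C)C[C@H](N)c1cc(C(F)(F)F)ccc1N1CCN(C(=O)CCC(N)=O)CC1`: > 10000 nM, a limit of the assay
Compound 3 `CC(C)C[C@H](N)c1cc(C(F)(F)F)ccc1N1CCN(C(=O)COc2ccc(O)cc2)CC1`: 4600 nM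

Going by the values given here, compound 3 holds the only single number in this assay; compound 1 carries two entries (the several entries of compound 1 in this assay, 120 nM; 1600 nM (2 entries)), and compound 2 sits at the limit (the limit of > 10000 nM in this assay, at which 1 of the 3 values shown sits). The move to compound 4 `CC(C)C[C@H](N)c1cc(C(F)(F)F)ccc1N1CCN(C(=O)CCC2CCCCC2)CC1` is cyclohexylmethyl in place of 4-hydroxyphenoxy on a saturated chain carbon bound to a carbonyl carbon. Among the compounds with values here, the one measured step in this part of the series, an at least 2.1-fold lower number from compound 2 to compound 3 (0.33 log units; beyond the scatter), went toward stronger binding and was at least modest. Within the data shown here, no step bears directly on a hydrocarbon-only tail, though compound 1, with its chlorinated aromatic tail, shows 120 nM; 1600 nM (2 entries). Compound 4 is expected near 1500 nM, between 400 nM and 6000 nM. This estimate means a 3.1-fold lower number from compound 3 to compound 4 (0.49 log units; beyond the scatter), a modest expected gain, not secure.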

Compound 4, inhibition constant: 5700 nM
Estimate against measurement, compound 4: 3.8-fold (0.58 log units) below; low and high end bracket the measured number.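

Replacing 4-hydroxyphenoxy with cyclohexylmethyl on a saturated chain carbon bound to a carbonyl carbon shows that this position tolerates an all-carbon ring with no hydrogen-bond donors or acceptors, with a 1.2-fold higher number from compound 3 to compound 4 (0.09 log units; within the scatter). Against the carbamoyl tail, the reading is an at least 1.7-fold lower number from compound 2 to compound 4 (0.24 log units; that floor lies within the scatter), so this step cannot be called a gain. Compound 2 stands at a limit of the assay: the limit of > 10000 nM in this assay, at which 1 of the 4 values shown sits.

From the compounds shown here alone, compound 1 gives no single number to set beside these tails: the several entries of compound 1 in this assay, 120 nM; 1600 nM (2 entries) How an amine, a carboxylic acid or a longer chain would read at this position remains open.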